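The compounds below may be only part of what the source reports. "The series", "measured", "known", "first", "only" and "open" are said of these compounds alone.

Working notes on the series.

Compound 1 `CC(O)(CSc1ccc(S(F)(F)(F)(F)F)cc1)C(=O)Nc1ccc(C#N)c(C(F)(F)F)c1` and compound 2 `CC(O)(CSc1ccc(S(F)(F)(F)(F)F)cc1)C(=O)Nc1ccc([N+](=O)[O-])c(C(F)(F)F)c1` are built on one core; compound 3 `CC(O)(CS(=O)(=O)c1cccc(S(F)(F)(F)(F)F)c1)C(=O)Nc1ccc(C#N)cc1C(F)(F)F` and compound 4 `CC(O)(CS(=O)(=O)c1cccc(S(F)(F)(F)(F)F)c1)C(=O)Nc1ccc([N+](=O)[O-])cc1C(F)(F)F` are built on another. The difference between the two cores is not broken down here.

In a functional assay on LNCaP cells (Homo sapiens) for antiproliferative activity, read by propidium iodide staining, with a stated time of 96 h (a higher number here means a weaker inhibitor, a lower number a stronger inhibitor), compound 1 gives 16900 nM. In this assay compound 2 gives 8700 nM. The change from compound 1 to compound 2 is nitro in place of cyano on an aromatic carbon, and the step it made is a 1.9-fold lower number from compound 1 to compound 2 (0.29 log units; within the scatter). In this assay compound 3 gives 12900 nM. The values of compound 1, compound 2 and compound 3 all lie within the usual scatter of one another, so no ranking of the three is drawn.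

Compound 4 carries the same kind of change on the second core: nitro in place of cyano on an aromatic carbon. The surroundings are not identical: in compound 2 the entering group is ortho to a trifluoromethyl group, in compound 4 it is meta to a trifluoromethyl group; in both it is para to a large group. This change is seen once among the measured compounds, so the expectation rests on a single pair.

Among the measured compounds shown here, the step from compound 3 to compound 4 is expected to be a 1.7-fold lower number from compound 3 to compound 4 (0.24 log units; within the scatter), because a 1.9-fold lower number from compound 1 to compound 2 (0.29 log units; within the scatter) was the only such step recorded and stayed within the scatter, and the estimate is kept close to that size. Compound 4 is expected to give 7500 nM in this assay, with the estimate spanning 3500 nM to 16000 nM.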

Compound 4, half-maximal inhibitory concentration: 6500 nM
Compound 4: the middle estimate sits 1.2-fold (0.06 log units) above what was measured; low and high end bracket the measured number.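

In this assay, nitro in place of cyano on an aromatic carbon gives a 2.0-fold lower number from compound 3 to compound 4 (0.30 log units; within the scatter), and this step agrees with the one on the other core: the same change on two cores in this assay, a 1.9-fold lower number (0.29 log units; within the scatter) from compound 1 to compound 2 and a 2.0-fold lower number (0.30 log units; within the scatter) from compound 3 to compound 4, 1.0-fold (0.01 log units) apart, within the scatter of two such steps Within these two pairs, the change therefore carries from one core to the other with no visible difference in the step, even though the surroundings are not identical, with the entering group in compound 4 meta to a trifluoromethyl group. It does not show that nitro and cyano truly differ in this read-out, since each step stays within the scatter, and two pairs in a single assay say nothing about a third core or about other cell lines.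

Open is what an amine, a carboxylic acid or a single chlorine atom would give on the same aromatic carbon, para to a large group, where only cyano and nitro stand among the compounds shown. Also open, on these data alone, is how a longer chain in place of the methyl group on the shared hydroxyl-bearing carbon would read in this assay, and whether any such change would produce a step beyond the scatter.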